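A nitro group added to a weak cell-growth inhibitor

A few compounds are considered here, and "the series" means these few. Any claim that something is new, unique, unknown or untested is made for them only; others in the source may bear on it.

Among the compounds with values here, compound 3 `CCN1C(=O)N(CC)C2C1N=C(SC)N2/N=C/C=C/c1ccccc1` is the only compound of this set with a measured number: in a functional assay on A549 cells (Homo sapiens) for inhibition, read by MTT assay, with a stated time of 72 h (a lower number here means a stronger inhibitor, a higher number a weaker inhibitor), compound 3 gives 21400 nM. Compound 1 `CN1C(=O)N(c2ccccc2)C2NC(=S)N(/N=C/C=C/c3ccccc3)C21` reaches only the limit of this assay, and compound 1 is recorded as > 100000 nM. Compound 2 `CCN1C(=O)N(CC)C2C1NC(=S)N2/N=C/C=C/c1ccccc1[N+](=O)[O-]` likewise stops at the limit, and compound 2 is recorded as > 100000 nM. Two of the three results thus sit at the limit of > 100000 nM in this assay, at which 2 of the 3 values shown sit, and compound 3 stands alone with a number. Within the data shown here, no step between two measured compounds that differ in a single place is available, so these data do not show how one change shifts the reading.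

Compound 4 `CCN1C(=O)N(CC)C2C1N=C(SC)N2/N=C/C=C/c1ccccc1[N+](=O)[O-]` differs from compound 3 by nitro in place of hydrogen on an aromatic carbon, ortho to a large group. Compound 2 also carries this nitro group, but its core differs from that of compound 3 as well, so no single step can be read from that pair. The step from compound 3 to compound 4 is expected to be small, toward weaker inhibition, a 1.9-fold higher number from compound 3 to compound 4 (0.27 log units; within the scatter). Compound 4 is therefore estimated at 40000 nM, within 10000 nM to 150000 nM.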

Compound 4, half-maximal inhibitory concentration: > 100000 nM
Compound 4 gave a limit, no number; the forecaster's own chance of this, stated with the estimate: 35%; middle value at least 2.5-fold (0.39 log units) away from the limit.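

Within the data shown here, this is the first step in the set that isolates a single change: with nitro in place of hydrogen on an aromatic carbon, ortho to a large group, this assay shows an at least 4.6-fold higher number from compound 3 to compound 4 (0.66 log units; beyond the scatter). At this position, then, the nitro group weakens inhibition beyond the usual scatter, something compound 2 could not show, as its core differs from that of compound 3 as well. The full size of the step stays unknown because the reading for compound 4 is a limit and not a number: the limit of > 100000 nM in this assay, at which 3 of the 4 values shown sit.

The compounds shown leave open whether another group at this same place, such as an amine or a methoxy group, would keep the reading of compound 3 or shift it. They also cannot tell how the nitro group would act on a different core.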